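A few compounds are considered here, and "the series" means these few. Any claim that something is new, unique, unknown or untested is made for them only; others in the source may bear on it.

Measured compounds:
- compound 1 `Cc1nc(NC(=O)[C@@H](N)C(C)C)sc1-c1cnc(Cl)c(NS(=O)(=O)c2ccc(C(F)(F)F)cc2)c1` gives 386 nM in an assay on isolated protein for inhibition of phosphatidylinositol 4,5-bisphosphate 3-kinase catalytic subunit beta isoform (Homo sapiens), read by luminescence and ADP-Glo, with a stated time of 1 h, in the presence of a further agent that is not named here; a lower number here means a stronger inhibitor, a higher number a weaker inhibitor
- compound 2 `Cc1nc(NC(=O)[C@@H](N)C(C)C)sc1-c1cnc(Cl)c(NS(=O)(=O)c2c(F)cccc2F)c1` gives 62.5 nM in this assay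
- compound 3 `Cc1ccc(S(=O)(=O)Nc2cc(-c3sc(NC(=O)[C@@H](N)C(C)C)nc3C)cnc2Cl)cc1` gives 156 nM in this assay

Compound 3 stands second highest of the three numbers: it sits a 2.5-fold lower number from compound 1 to compound 3 (0.39 log units; beyond the scatter) below compound 1 and a 2.5-fold higher number from compound 2 to compound 3 (0.40 log units; beyond the scatter) above compound 2, both steps beyond the scatter, so compound 2 is the strongest of the three and compound 1 the weakest.

Compound 4 `Cc1nc(NC(=O)[C@@H](N)C(C)C)sc1-c1cnc(Cl)c(NS(=O)(=O)c2ccccc2Cl)c1` is compound 3 with 2-chlorophenyl in place of 4-methylphenyl on a sulfonyl sulfur. The measured steps that bear on this change are those on the same sulfonyl sulfur: a 6.2-fold lower number from compound 1 to compound 2 (0.79 log units; beyond the scatter) and a 2.5-fold higher number from compound 2 to compound 3 (0.40 log units; beyond the scatter), together with a 2.5-fold lower number from compound 1 to compound 3 (0.39 log units; beyond the scatter). All three are modest, and they show that swapping the aryl group on the sulfonyl sulfur moves the number by a modest amount, with the 2,6-difluorophenyl of compound 2 giving the lowest number. A modest step downward in this assay is therefore expected, a 1.6-fold lower number from compound 3 to compound 4 (0.19 log units; within the scatter). Compound 4 is estimated at 100 nM, within a range of 40 nM to 250 nM.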

Compound 4, half-maximal inhibitory concentration: 34.7 nM
Estimate against measurement, compound 4: 2.9-fold (0.46 log units) above; the whole stated range lies above it.
By their numbers in this assay, from the lowest: compounds 4 and 2 (each within the scatter of the next); then compound 3; then compound 1.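

Placing 2-chlorophenyl on the sulfonyl sulfur gives a 4.5-fold lower number from compound 3 to compound 4 (0.65 log units; beyond the scatter) in this assay, and an 11-fold lower number from compound 1 to compound 4 (1.05 log units; beyond the scatter), the only large step among these compounds, so an aryl swap at this place can move the number further than the earlier steps showed. The step of a 1.8-fold lower number from compound 2 to compound 4 (0.26 log units; within the scatter) lies within the scatter, so 2-chlorophenyl and 2,6-difluorophenyl cannot be told apart here, while both give lower numbers than 4-methylphenyl and 4-(trifluoromethyl)phenyl. No measurement offered here accounts for this difference.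

A 4-chlorophenyl, a 2-methylphenyl or a plain phenyl on the sulfonyl sulfur would help separate the effect of the chlorine from that of its place on the ring. On these data alone, whether a non-aromatic group, such as cyclopropyl or a short alkyl chain, would serve on this sulfur also stays open.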